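Thiophen-2-yl in place of furan-3-yl on a shared core

The source may report more compounds than this note shows. Statements on the series, on what has been measured and on what is new or still open speak of the compounds shown alone.

Of the compounds shown here, three built on one core have been measured in an assay on HeLa cells for displacement of a labelled ligand from adenosine receptor A3 (Homo sapiens), read by radioligand binding, with a stated time of 180 min, tested at 1 uM; a higher number here means more inhibition at the concentration tested (going by the name of the read-out), a lower number less inhibition. Compound 1 `CC1=C(C(=O)OC(C(F)(F)F)C(F)(F)F)C(c2ccoc2)NC(=O)N1` gives 1%. Compound 2 `CC(C)OC(=O)C1=C(C(F)(F)F)NC(=O)NC1c1ccoc1` gives 1%, and compound 3 `CCOC(=O)C1=C(C(F)(F)F)NC(=O)NC1c1ccoc1` gives 1%. Compound 2 therefore stands level with compounds 1 and 3 at the digits shown: the single measured step, no change at the digits printed from compound 2 to compound 3 (within the scatter), lies within the scatter, and the values of compounds 1 and 2 likewise show no difference beyond it.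

Compound 4 `CC(C)OC(=O)C1=C(C(F)(F)F)NC(=O)NC1c1cccs1` has not yet been measured in this assay. It differs from compound 2 in one place: thiophen-2-yl in place of furan-3-yl on a saturated ring carbon. Within the data shown here, no measured step bears directly on this change; the step from compound 2 to compound 3 alters the ester only and says nothing about the ring on the saturated ring carbon. The account can rest only on the fact that every measured compound sits at the bottom of the scale, so the step of a number 2 percentage points higher from compound 2 to compound 4 (within the scatter) is expected to be none beyond the scatter. Because compound 2 gives 1%, compound 4 is estimated at 3%, with a range from -8% to 20%.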

Compound 4, a percentage reported as inhibition, at one concentration (the size of the read-out at that concentration, not a potency): 7%
Compound 4: middle estimate off by 4 percentage points, on the low side; the range from low to high includes it.
By their numbers in this assay, from the lowest: compounds 1, 2, 3 and 4 (each within the scatter of the next).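

Among these compounds, the first measured exchange at the saturated ring carbon, which lies next to the ring nitrogen and next to the ring atom bearing the isopropoxycarbonyl group, gives a number 6 percentage points higher from compound 2 to compound 4 (within the scatter) in this assay. Among the compounds shown here, the earlier compounds varied only the ester and the neighbouring ring substituent and all carried furan-3-yl, so this is the first sign that the ring on this carbon can be exchanged without a step beyond the scatter, at least for this pair of five-membered aromatic rings with the isopropoxycarbonyl group in place. The exchange replaces the ring oxygen with sulfur and moves the point of attachment in a single step, so the result covers the two changes together and cannot assign anything to either one alone.

The compounds shown leave open whether furan-2-yl or thiophen-3-yl, which would separate those two changes, or a larger group such as phenyl or a pyridine ring on this carbon would give a reading beyond the scatter. They also give no explanation for the readings at this position, as no measurement here speaks to a cause.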